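Substituent exchange on the saturated ring carbon: compound 3

A few compounds are considered here, and "the series" means these few. Any claim that something is new, unique, unknown or untested is made for them only; others in the source may bear on it.

Measured so far:
compound 1 `Cc1cc(O)c(C2=NN(c3ccc(S(N)(=O)=O)cc3)C(c3ccccc3Cl)C2)cc1Cl`: 8320 nM
compound 2 `Cc1cc(O)c(C2=NN(c3ccc(S(N)(=O)=O)cc3)C(/C=C/c3ccccc3)C2)cc1Cl`: 59500 nM

In a functional assay on MDA-MB-435 cells (Homo sapiens) for antiproliferative activity, with a stated time of 48 h (on this read-out higher numbers stand for lower toxicity in this test and lower numbers for higher toxicity in this test), compound 1 gives 8320 nM and compound 2 gives 59500 nM. Going by the values given here, compound 2 holds the highest of the two numbers; its nearest neighbour is compound 1, reached by the single measured step of a 7.2-fold higher number from compound 1 to compound 2 (0.85 log units; beyond the scatter), which accompanied exchange of the group on a saturated ring carbon.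

Compound 3 `COc1ccc(C2CC(c3cc(Cl)c(C)cc3O)=NN2c2ccc(S(N)(=O)=O)cc2)cc1OC` differs from compound 2 by 3,4-dimethoxyphenyl in place of 2-phenylethenyl on a saturated ring carbon. Among the compounds with values here, the one step that bears on this change is a 7.2-fold higher number from compound 1 to compound 2 (0.85 log units; beyond the scatter): there a 2-chlorophenyl group on the same ring carbon gave way to 2-phenylethenyl and the number rose. Compound 3 again carries a six-membered aromatic ring of carbon only on that carbon, though 3,4-dimethoxyphenyl is not 2-chlorophenyl, so the size of the reversal is uncertain. A move back downward, short of the full step, is expected. For compound 3, the expected step is a 3.3-fold lower number from compound 2 to compound 3 (0.52 log units; beyond the scatter). Compound 3 is estimated at 18000 nM, with a range from 6000 nM to 50000 nM.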

Compound 3, concentration lethal to 50% of the cells: > 100000 nM
Compound 3: no number, only a limit (the forecaster's own chance of this, stated with the estimate: 10%); at least 5.5-fold (0.74 log units) between middle value and limit.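

In this assay compound 3 gives no number, only a limit of the assay: the limit of > 100000 nM in this assay, at which 1 of the 3 values shown sits. Against 2-phenylethenyl, the reading is an at least 1.6-fold higher number from compound 2 to compound 3 (0.22 log units; that floor lies within the scatter), which fixes no order between these two groups on the saturated ring carbon. Against 2-chlorophenyl, the reading is firmer, at an at least 12-fold higher number from compound 1 to compound 3 (1.07 log units; beyond the scatter); both groups carry one six-membered aromatic ring of carbon only, so in this pair such a ring on this carbon does not by itself keep the number low, and what is attached to the ring goes with a clear difference in the read-out.

The compounds shown leave open how far the value of compound 3 lies past its limit, and whether the shift follows the 3,4-dimethoxyphenyl group as a whole or a single methoxy group on the ring. Also open, on these data alone, is where the number would fall with an aminophenyl group, a phenyl ring bearing a carboxylic acid, or a saturated butyl chain on this carbon.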